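The source may report more compounds than this note shows. Statements on the series, on what has been measured and on what is new or still open speak of the compounds shown alone.

Two members of this series carry numbers in a functional assay on NCI-H1975 cells (Homo sapiens) for antiproliferative activity, read by MTT assay, with a stated time of 72 h; on this read-out higher numbers stand for weaker inhibition and lower numbers for stronger inhibition. Compound 1 `C=CC(=O)Nc1cc(Nc2nc(C)cc(-c3cn(C)c4ccccc34)n2)c(OC)cc1N(C)CCN(C)C` gives 4810 nM in this assay. Compound 2 `C=CC(=O)Nc1cc(Nc2nccc(-c3cn(C)c4ccc(F)cc34)n2)c(OC)cc1N(C)CCN(C)C` gives 254 nM, the lowest of the two values, with compound 1 as its nearest neighbour at a gap beyond the scatter. Among the compounds with values here, compounds 1 and 2 differ in two places at once, so no single step between them can be read off; their two values show only that the compound carrying the methyl on the shared core but no fluorine sits far above the compound carrying the fluorine and a hydrogen in the methyl's place.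

Compound 3 `C=CC(=O)Nc1cc(Nc2nc(C)cc(-c3cn(C)c4ccc(F)cc34)n2)c(OC)cc1N(C)CCN(C)C` has not been measured in this assay. Relative to compound 2 it differs by methyl in place of hydrogen on an aromatic carbon. A step upward, beyond the scatter, is expected because compound 1 with the same methyl gives 4810 nM, although the missing fluorine in compound 1 leaves the share of the methyl alone uncertain. The expected step from compound 2 to compound 3 is a 5.9-fold higher number from compound 2 to compound 3 (0.77 log units; beyond the scatter). Compound 3 is estimated at 1500 nM, within a range from 400 nM to 5500 nM.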

Compound 3, half-maximal inhibitory concentration: 3830 nM
Estimate against measurement, compound 3: 2.6-fold (0.41 log units) below, and the stated range covers the measured number.
By their numbers in this assay, from the lowest: compound 2; then compounds 3 and 1 (each within the scatter of the next).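

In this assay methyl in place of hydrogen on the aromatic carbon next to the ring nitrogen can now be read as a single change, a 15-fold higher number from compound 2 to compound 3 (1.18 log units; beyond the scatter), with the 5-fluoro-1-methyl-1H-indol-3-yl group held constant, so this small addition alone costs a large part of the activity of compound 2. With that methyl present, the step that brings in the fluoro gives a 1.3-fold lower number from compound 1 to compound 3 (0.10 log units; within the scatter), which places the wide gap between compound 1 and compound 2 with the methyl and not with the fluoro. The data on hand give no measured reason for the size of the methyl step.

On these data alone, it remains open whether any other group at this carbon, such as an amino group, a methoxy group or a chlorine atom, behaves like the methyl, or whether the methyl is a special case. Within the data shown here, also open is what the fluoro contributes when hydrogen occupies this carbon, since the two fluoro-bearing compounds show it only beside the methyl step and no pair isolates it there.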